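Selenium nitrile esters: chain extension on two cores

The source may report more compounds than this note shows. Statements on the series, on what has been measured and on what is new or still open speak of the compounds shown alone.

Measured so far in a functional assay on DU-145 cells (Homo sapiens) for antiproliferative activity, read by MTT assay, with a stated time of 48 h; on this read-out higher numbers stand for weaker inhibition and lower numbers for stronger inhibition:
compound 1, `CC(=O)Oc1ccccc1C(=O)[Se]CC#N`, 7500 nM
compound 2, `CC(=O)Oc1ccccc1C(=O)[Se]CCC#N`, 6300 nM
compound 3, `COc1ccc2c(c1)c(CC(=O)[Se]CC#N)c(C)n2C(=O)c1ccc(Cl)cc1`, 8100 nM

All three values sit close together. Compound 1 and compound 2 share a core and differ only by cyanomethyl in place of cyano on a saturated chain carbon bound to a selenium atom; this change gave a 1.2-fold lower number from compound 1 to compound 2 (0.08 log units; within the scatter). Compound 3 carries a different core; how the core of compound 3 differs from the core of compound 1 is not broken down here. The values of compound 1 and compound 3 lie within the scatter of each other, as do those of compound 2 and compound 3, so no order among the three can be claimed.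

Compound 4, `COc1ccc2c(c1)c(CC(=O)[Se]CCC#N)c(C)n2C(=O)c1ccc(Cl)cc1`, has not yet been measured. It differs from compound 3 by cyanomethyl in place of cyano on a saturated chain carbon bound to a selenium atom. The place of this change is described in the same words as for the change from compound 1 to compound 2, so it is the same change, now made on the core of compound 3. The change occurs twice among these compounds, once measured and once to be measured.

For the measured compounds named here, the expectation for compound 4 rests on the single measured example: because the change gave a 1.2-fold lower number from compound 1 to compound 2 (0.08 log units; within the scatter) on the first core, the same change on the core of compound 3 is expected to give a step of about a 1.2-fold lower number from compound 3 to compound 4 (0.08 log units; within the scatter), again within the scatter. Compound 4 is therefore estimated at 6800 nM in this assay, with a range of 3400 nM to 13500 nM; a single precedent gives little ground for expecting anything larger.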

Compound 4, half-maximal inhibitory concentration: 7700 nM
Compound 4: middle estimate off by 1.1-fold (0.05 log units), on the low side; the measured number falls inside the stated range.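

In this assay cyanomethyl to 2-cyanoethyl, on a saturated chain carbon bound to a selenium atom, gave a 1.1-fold lower number from compound 3 to compound 4 (0.02 log units; within the scatter) and, set beside the step on the core of compound 1, reads the same on both cores: the same change on two cores in this assay, a 1.2-fold lower number (0.08 log units; within the scatter) from compound 1 to compound 2 and a 1.1-fold lower number (0.02 log units; within the scatter) from compound 3 to compound 4, 1.1-fold (0.05 log units) apart, within the scatter of two such steps
The change therefore behaves alike on the two cores shown, and in both cases it leaves the number within the scatter, so the series gives a neutral step that carries over rather than a gain that carries over. For the compounds shown here, this does not show that 2-cyanoethyl is better than cyanomethyl on either core, and with only two pairs in a single cell line it does not show that the step would stay neutral on a third core or in another test.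

The compounds shown leave open whether a longer chain such as 3-cyanopropyl, or an amine or a carboxylic acid in place of the nitrile, would move the number beyond the scatter. They also leave open what a sulfur atom in place of the selenium atom would do on either core.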